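An Ester in Place of the Aryl Group of Compound 3

A few compounds are considered here, and "the series" means these few. Any claim that something is new, unique, unknown or untested is made for them only; others in the source may bear on it.

Compound 3 `CCS[C@@H]1[C@H](SCC)[C@@H](Cn2cc(-c3ccc(OC)cc3)nn2)O[C@H]1n1cc(C)c(=O)[nH]c1=O` gives 38800 nM in a functional assay on A549 cells (Homo sapiens) for cytotoxicity, read by MTT assay, with a stated time of 72 h (a lower number here means that less compound is needed, a higher number that more compound is needed for the effect), and so stands highest among the two numbers shown. Compound 1 `CCS[C@@H]1[C@H](SCC)[C@@H](Cn2cc(-c3ccc(OC)cc3)nn2)O[C@H]1n1ccc(=O)[nH]c1=O` gives 16800 nM in this assay, and the step of a 2.3-fold higher number from compound 1 to compound 3 (0.36 log units; beyond the scatter) is modest. Compound 2 `CCS[C@@H]1[C@H](SCC)[C@@H](Cn2cc(-c3ccc(F)cc3)nn2)O[C@H]1n1cc(C)c(=O)[nH]c1=O` reaches only a limit in this assay, namely >= 100000 nM. That limit is the limit of >= 100000 nM in this assay, at which 1 of the 3 values shown sits, and the step of an at least 2.5-fold lower number from compound 2 to compound 3 (0.41 log units; beyond the scatter) is at least modest.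

Compound 4 `CCOC(=O)c1cn(C[C@H]2O[C@@H](n3cc(C)c(=O)[nH]c3=O)[C@H](SCC)[C@@H]2SCC)nn1` differs from compound 3 by ethoxycarbonyl in place of 4-methoxyphenyl on an aromatic carbon. Going by the values given here, no measured step exchanges the whole group on that carbon of the five-membered ring; the only change seen there, from fluoro to methoxy on the phenyl, moved the number at least modestly, and compound 2 with the fluoro sits at the limit. Because the step of an at least 2.5-fold lower number from compound 2 to compound 3 (0.41 log units; beyond the scatter) shows that what sits on this carbon matters, a modest rise in this assay is expected for compound 4, with a fair chance that only a limit is reported. Compound 4 is therefore estimated at 65000 nM, between 20000 nM and 200000 nM, a step of a 1.7-fold higher number from compound 3 to compound 4 (0.22 log units; within the scatter) expected.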

Compound 4, half-maximal effective concentration: >= 100000 nM
Compound 4: no number, only a limit (the forecaster's own chance of this, stated with the estimate: 45%); at least 1.5-fold (0.18 log units) between middle value and limit.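

In this assay the exchange of the whole 4-methoxyphenyl group for ethoxycarbonyl on this carbon gives an at least 2.5-fold higher number from compound 3 to compound 4 (0.41 log units; beyond the scatter), so the change reaches beyond the earlier edit within the phenyl group. Among the compounds sharing the core of compound 3, only the one carrying 4-methoxyphenyl gives a number, and compound 4 reaches only a limit, which places this ester with the fluoro compound, although the step from compound 2 to compound 4 cannot be read. Both of these compounds now rest at the same limit: the limit of >= 100000 nM in this assay, at which 2 of the 4 values shown sit.

The compounds shown leave open whether an amine, a carboxylic acid or an unsubstituted phenyl group on this carbon would give a number. On these data alone, it also remains open whether a longer chain on the ester oxygen would do so.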